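The source may hold more compounds than are shown below. What is called first, only, known or untested is meant among the compounds shown, and "the series" means these compounds.

Measured so far in a physicochemical assay for solubility, read by HPLC, using the shake flask method, measured as kinetic solubility, with a stated time of 2 h, at pH 7.4; a lower number here means a less soluble compound, a higher number a more soluble compound:
compound 1 `Cc1cc(NCc2ccccn2)n2ncc(Br)c2n1` — 89300 nM
compound 2 `Cc1cc(NCCCc2ccccn2)n2nc(C)c(-c3ccccc3)c2n1` — 5900 nM

Compound 1 stands highest of the two numbers in this assay; the nearest, compound 2, sits well below it, and that gap lies beyond the scatter. Among the compounds with values here, no single-change step between the measured compounds is available, so the two values can only be read side by side: compound 2 gives 5900 nM and differs from compound 1 in several places at once, among them a six-membered aromatic ring of carbon only on its core.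

Compound 3 `Cc1cc(NCc2ccccn2)n2ncc(-c3cccc(Cl)c3)c2n1` is the next compound for this assay. It differs from compound 1 by 3-chlorophenyl in place of bromo on an aromatic carbon.

Expectation for this assay: a drop well beyond the scatter. Within the data shown here, the one measured compound bearing an added aromatic ring on the core, compound 2, sits far below compound 1, and compound 3 carries an added aromatic ring of its own. The step from compound 1 to compound 3 is expected to be an 11-fold lower number from compound 1 to compound 3 (1.05 log units; beyond the scatter). Compound 3 is estimated at 8000 nM, with a range from 2500 nM to 25000 nM.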

Compound 3, solubility: < 5000 nM
Compound 3 ended at the assay's limit; the forecaster's own chance of this, stated with the estimate: 5%; middle value at least 1.6-fold (0.20 log units) from the limit.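

In this assay compound 3 gives < 5000 nM, which is a limit of the assay and not a number: the limit of < 5000 nM in this assay, at which 1 of the 3 values shown sits. Within the data shown here, the exchange of bromo for 3-chlorophenyl on an aromatic carbon of a five-membered aromatic ring with 2 nitrogen gives an at least 17-fold lower number from compound 1 to compound 3 (1.25 log units; beyond the scatter), the first step that rests on a single change. The earlier pair offered no such reading, as its two compounds differ in several places at once, whereas here a large move to a lower number is tied to this one position and this one exchange.

From the compounds shown here alone, how far the true value of compound 3 lies past the limit stays open, and with it the full size of the step. Also open, going by these compounds, is whether the 3-chlorophenyl group as a whole carries the step or only part of it, and whether an aromatic ring bearing an amine or a carboxylic acid at this same carbon would give a number closer to that of compound 1, at 89300 nM.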